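Methyl on the N-phenyl ring of a pyrazole benzamide

A few compounds are considered here, and "the series" means these few. Any claim that something is new, unique, unknown or untested is made for them only; others in the source may bear on it.

Compound 1, `COc1cccc(-n2cc(NC(=O)c3cccc(NS(=O)(=O)c4ccccc4)c3)cn2)c1`, in a functional assay on HepG2 cells (Homo sapiens) for inhibition, read by MTT assay, with a stated time of 48 h (a higher number here means a weaker inhibitor, a lower number a stronger inhibitor), compound 1 gives 25000 nM.
Compound 2, `Cn1cc(NC(=O)c2ccc(NS(=O)(=O)c3ccccc3)cc2)cn1`, in this assay compound 2 gives only the limit > 100000 nM, which is a limit of the assay and not a number.
Compound 3, `O=C(Nc1cnn(-c2ccccc2)c1)c1ccc(NS(=O)(=O)c2ccccc2)cc1`, in this assay compound 3 gives 21500 nM.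

Of the two numbers shown, compound 3 and compound 1 stand within the scatter of each other, and compound 2 gives only a limit (the limit of > 100000 nM in this assay, at which 1 of the 3 values shown sits). Among the compounds with values here, the one step that can be sized is the exchange of phenyl for methyl on the aromatic nitrogen, which gives an at least 4.6-fold lower number from compound 2 to compound 3 (0.66 log units; beyond the scatter).

Compound 4, `Cc1ccc(-n2cc(NC(=O)c3ccc(NS(=O)(=O)c4ccccc4)cc3)cn2)cc1`, differs from compound 3 by methyl in place of hydrogen on an aromatic carbon. Within the data shown here, no measured step touches this position; the step from compound 2 to compound 3 concerns the group on the aromatic nitrogen, not a substituent on the phenyl that is already present in compound 3. With nothing in the measured pairs that speaks for a change at this position, no step beyond the scatter in this assay is expected, and the estimated step is a 1.1-fold lower number from compound 3 to compound 4 (0.03 log units; within the scatter). Compound 4 is therefore expected to give about 20000 nM, within 7000 nM to 60000 nM.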

Compound 4, half-maximal inhibitory concentration: 18100 nM
Estimate against measurement, compound 4: 1.1-fold (0.04 log units) above; low and high end bracket the measured number.
By their numbers in this assay, from the lowest: compounds 4, 3 and 1 (each within the scatter of the next). At a limit, above all of these: compound 2.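

Methyl in place of hydrogen on an aromatic carbon of the N-phenyl ring, para to a large group, is the first change at this position, and this assay gives a 1.2-fold lower number from compound 3 to compound 4 (0.07 log units; within the scatter). Phenyl to 4-methylphenyl therefore leaves compound 3 and compound 4 within the scatter of each other, and this position accepts one added methyl without a step that can be told apart from that scatter. The larger step on the aromatic nitrogen also holds with the 4-methylphenyl group, which gives an at least 5.5-fold lower number from compound 2 to compound 4 (0.74 log units; beyond the scatter), and that step has only a lower bound, since the value of compound 2 is a limit of the assay and not a number: the limit of > 100000 nM in this assay, at which 1 of the 4 values shown sits.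

From the compounds shown here alone, a single methyl says little about this position as a whole, and whether an amine, a carboxylic acid or a longer chain in the same place would give a step beyond the scatter stays open. Compound 1 differs from compound 4 in more than one place, so the methoxy group on its phenyl ring cannot be judged on its own from the compounds shown.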